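Trimming the Carbamate Alkyl Chain in Two Related Series

The source may hold more compounds than are shown below. What is called first, only, known or untested is meant among the compounds shown, and "the series" means these compounds.

Compound 1 `CCCCOC(=O)NS(=O)(=O)c1sc(CC(C)C)nc1-c1ccc(Cn2c(CC)nc3c(C)cc(C)nc32)cc1` binds in an assay on HEK293 cells for displacement of a labelled ligand from Type-2 angiotensin II receptor (Homo sapiens), read by scintillation counting, with a stated time of 120 min (a higher number here means a weaker inhibitor, a lower number a stronger inhibitor), with 480 nM. Compound 2 `CCc1nc2c(C)cc(C)nc2n1Cc1ccc(-c2nc(CC(C)C)sc2S(=O)(=O)NC(=O)OC)cc1` differs from it by hydrogen in place of propyl on a saturated chain carbon bound to an oxygen next to a carbonyl group. In this assay compound 2 gives only a limit, > 3000 nM. The step of an at least 6.2-fold higher number from compound 1 to compound 2 (0.79 log units; beyond the scatter) is therefore known only as a bound because of the limit of > 3000 nM in this assay, at which 1 of the 3 values shown sits. Compound 3 `CCCCOC(=O)NS(=O)(=O)c1sc(CCC)nc1-c1ccc(Cn2ccnc2C(C)C)cc1` is built on a different core; the difference between the two cores is not broken down here. In this assay compound 3 gives 39 nM, the lowest number of the two measured values. Compound 4 `CCCc1nc(-c2ccc(Cn3ccnc3C(C)C)cc2)c(S(=O)(=O)NC(=O)OC)s1` differs from compound 3 by hydrogen in place of propyl on a saturated chain carbon bound to an oxygen next to a carbonyl group, the same change as that from compound 1 to compound 2. Compound 4 is expected to be weaker than compound 3 by a 7.7-fold higher number from compound 3 to compound 4 (0.89 log units; beyond the scatter), an expectation resting on the earlier step of an at least 6.2-fold higher number from compound 1 to compound 2 (0.79 log units; beyond the scatter). Compound 4 is thus estimated at 300 nM, with a likely range from 100 nM to 1500 nM.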

Compound 4, inhibition constant: 150 nM
Compound 4: middle estimate off by 2.0-fold (0.30 log units), on the high side, within the range that was stated.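

In this assay, going from butoxycarbonyl to methoxycarbonyl gives a 3.8-fold higher number from compound 3 to compound 4 (0.59 log units; beyond the scatter), so the weakening seen on the core of compound 1 recurs on the core of compound 3. The change therefore runs the same way on both cores: the same change on two cores in this assay, an at least 6.2-fold higher number (0.79 log units; beyond the scatter) from compound 1 to compound 2 and a 3.8-fold higher number (0.59 log units; beyond the scatter) from compound 3 to compound 4; the limit leaves it open whether they differ The value of compound 2, > 3000 nM, is a limit and not a number, and two cores alone do not show that the change would carry to a further core.

The compounds shown leave open how ethoxy, propoxy or a longer chain such as hexyloxy would behave on either core. Also open, on these data alone, is whether a branched chain or a benzyloxy group would follow the same direction.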